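The source may hold more compounds than are shown below. What is called first, only, known or untested is meant among the compounds shown, and "the series" means these compounds.

In a functional assay on MCF7 cells (Homo sapiens) for cytotoxicity, read by MTT assay, with a stated time of 48 h (a higher number here means a weaker inhibitor, a lower number a stronger inhibitor), compound 1 `CCCCCCCCCCCCNC(=O)[C@@H](NC(=O)c1ccco1)[C@@H](C)O` gives 67500 nM; compound 2 `CCCCCCCCCCCCNC(=O)[C@@H](NC(=O)c1cc2ccccc2o1)[C@@H](C)O` gives 20900 nM; compound 3 `CCCCCCCCCCCCNC(=O)[C@@H](NC(=O)c1nccc2ccccc12)[C@@H](C)O` gives 50500 nM.

Compound 1 carries the highest of the three numbers in this assay. Compound 3 sits closest to it, with a 1.3-fold lower number from compound 1 to compound 3 (0.13 log units; within the scatter), while compound 2 lies furthest away, with a 3.2-fold lower number from compound 1 to compound 2 (0.51 log units; beyond the scatter). Compound 4 `CCCCCCCCCCCCCCCCCCNC(=O)[C@@H](NC(=O)c1ccco1)[C@@H](C)O` differs from compound 1 by hexyl in place of hydrogen on a saturated chain carbon, ten or more bonds along the chain from an amide-type nitrogen. For the measured compounds named here, every measured step exchanges the ring attached to the carbonyl carbon and leaves the long chain as it is, so no measured step speaks to lengthening that chain. With nothing to guide the direction, the step of a 1.1-fold lower number from compound 1 to compound 4 (0.05 log units; within the scatter) is expected to stay close to the scatter. Compound 4 is therefore estimated at 60000 nM, within a range from 20000 nM to 180000 nM.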

Compound 4, half-maximal inhibitory concentration: 21400 nM
Compound 4: the middle estimate sits 2.8-fold (0.45 log units) above what was measured, and the stated range covers the measured number.
By their numbers in this assay, from the lowest: compounds 2 and 4 (each within the scatter of the next); then compounds 3 and 1 (each within the scatter of the next).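

Hexyl in place of hydrogen on a saturated chain carbon brings a 3.2-fold lower number from compound 1 to compound 4 (0.50 log units; beyond the scatter) in this assay, so the number responds to this long chain and not only to the ring on the carbonyl carbon. The furan-2-yl ring stays unchanged in this step, which isolates the chain as the part that differs. Nothing measured here explains the shift. As far as these compounds go, a still longer chain, or an amine placed on this chain, remains open. So does whether the same lengthening would lower the number with 1-benzofuran-2-yl on the carbonyl carbon.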